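A few compounds are considered here, and "the series" means these few. Any claim that something is new, unique, unknown or untested is made for them only; others in the source may bear on it.

Measured so far in a functional assay on A549 cells (Homo sapiens) for inhibition, read by CCK-8 assay, with a stated time of 72 h, tested at 8 uM; a lower number here means less inhibition of growth, a higher number more inhibition of growth at the concentration tested:
- compound 1 `COc1ccc(SCc2ccc(/C=C/C(=O)Nc3ccccc3N)cc2)cc1OC`: 80.6%
- compound 2 `Cc1cc(C)cc(SCc2ccc(/C=C/C(=O)Nc3ccccc3N)cc2)c1`: 47.3%
- compound 3 `CCc1ccc(SCc2ccc(/C=C/C(=O)Nc3ccccc3N)cc2)cc1`: 68.6%

Compound 3, at 68.6%, stands second highest of the three in this assay, under compound 1 and over compound 2, with both gaps beyond the scatter. Next is compound 4 `Cc1ccc(SCc2ccc(/C=C/C(=O)Nc3ccccc3N)cc2)cc1`, which differs by hydrogen in place of methyl on a saturated chain carbon bound to an aromatic carbon, so that 4-ethylphenyl becomes 4-methylphenyl. Among the compounds with values here, no measured pair isolates this change. The nearest evidence is the three exchanges of the whole group on sulfur: a number 33.3 percentage points lower from compound 1 to compound 2 (beyond the scatter), a number 12 percentage points lower from compound 1 to compound 3 (beyond the scatter) and a number 21.3 percentage points higher from compound 2 to compound 3 (beyond the scatter). All three lie beyond the scatter, so this assay does respond to that group, but each exchange alters far more than the single carbon lost here. Compound 2, which also bears methyl groups rather than ethyl, gives 47.3%, though its substitution differs, so this is only a weak hint of a downward lean. A small step is therefore expected, slightly downward and probably not beyond the scatter. The expected step is a number 4.6 percentage points lower from compound 3 to compound 4 (within the scatter). For compound 4 the estimate is 64%, with an expected range from 50% to 77%.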

Compound 4, percent growth inhibition at one concentration: 48.3%
Compound 4: the middle estimate sits 15.7 percentage points above what was measured; measured number outside the range, below it.
By their numbers in this assay, from the lowest: compounds 2 and 4 (each within the scatter of the next); then compound 3; then compound 1.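

In this assay, within the data shown here, the single carbon at this position carries real weight: hydrogen in place of methyl on a saturated chain carbon bound to an aromatic carbon, which turns 4-ethylphenyl into 4-methylphenyl, gives a number 20.3 percentage points lower from compound 3 to compound 4 (beyond the scatter), and this is the first step that isolates one small change to the group on sulfur. The new compound also changes the reading of the lowest values, since exchanging the whole group on sulfur gives a number 1 percentage points higher from compound 2 to compound 4 (within the scatter), so that pair cannot be ordered and the two differently methylated rings stand level in this assay. Against the methoxy-bearing group, the same 4-methylphenyl group gives a number 32.3 percentage points lower from compound 1 to compound 4 (beyond the scatter), and nothing measured here accounts for the weight of one carbon at this place.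

Still open, as far as these compounds go, is whether a longer chain such as propyl or isopropyl at the same place would continue the trend from methyl to ethyl or reverse it. Also open, from the compounds shown here alone, is how a single methoxy group, or an amine in that place, would sit relative to compound 1 and compound 3, which would show whether the high value depends on the ethyl or methoxy groups themselves.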